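The compounds below may be only part of what the source reports. "The series", "measured", "known", "first", "only" and "open" are said of these compounds alone.

Measured in an in vitro ADME assay on microsomes (Homo sapiens) for metabolic stability; a higher number here means that the compound lasts longer, a lower number that the compound disappears faster:
- compound 1 `CCC(CC)Nc1nc(OC)c(-c2ccc(Cl)cc2Cl)nc1C`: 0.933 h
- compound 2 `CCC(CC)Nc1nc(C)c(-c2ccc(Cl)cc2Cl)nc1C`: 0.483 h
- compound 3 `CCc1nc(N(CC2CC2)CC2CC2)c(CC)nc1-c1ccc(Cl)cc1Cl`: 0.133 h

Compound 1 shares the upper end of these numbers with compound 2, while compound 3 lies well below both. The unmeasured compound 4 `CCc1nc(-c2ccc(Cl)cc2Cl)c(OC)nc1NC(CC)CC` differs from compound 1 by methyl in place of hydrogen on a saturated chain carbon bound to an aromatic carbon, which turns methyl into ethyl. For the measured compounds named here, the only measured single change, methyl in place of methoxy on an aromatic carbon, gave a 1.9-fold lower number from compound 1 to compound 2 (0.29 log units; within the scatter). It is a different change, so it offers only loose guidance. A modest drop, a 1.4-fold lower number from compound 1 to compound 4 (0.16 log units; within the scatter), is expected in this assay, with no step beyond the scatter. For compound 4 the estimated half-life is 0.65 h, with an expected range from 0.3 h to 1.3 h.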

Compound 4, half-life: 0.7 h
The estimate for compound 4 lay 1.1-fold (0.03 log units) below the measured number, within the range that was stated.
By their numbers in this assay, from the lowest: compound 3; then compounds 2, 4 and 1 (each within the scatter of the next).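

In this assay, turning methyl into ethyl on a saturated chain carbon bound to an aromatic carbon gives a 1.3-fold lower number from compound 1 to compound 4 (0.12 log units; within the scatter), so this one added carbon is not resolved from no change at all. For the compounds shown here, this is the first single-change reading at this place, since the earlier step concerned the methoxy group. Nothing available explains this result.

As far as these compounds go, it remains open whether a longer chain such as propyl, or an amine, would also stay within the scatter here. Also open, from the compounds shown here alone, is whether ethyl would behave the same alongside methyl in place of methoxy.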